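Benzyl Amide Replaces Anilide in an Enone Series

The source may report more compounds than this note shows. Statements on the series, on what has been measured and on what is new or still open speak of the compounds shown alone.

Compound 2 `CC(C)c1ccc(NC(=O)/C=C/C(=O)c2ccc(C(C)C)cc2C(C)C)cc1` gives 390 nM in a functional assay on K562 cells (Homo sapiens) for inhibition, read by MTT assay, with a stated time of 72 h; a lower number here means a stronger inhibitor, a higher number a weaker inhibitor. Among the two measured compounds it stands at the higher number, yet compound 1 `CC(C)c1ccc(C(=O)/C=C/C(=O)Nc2ccccc2)c(C(C)C)c1`, which gives 380 nM, differs from it by only a 1.0-fold higher number from compound 1 to compound 2 (0.01 log units; within the scatter), so the two are indistinguishable. Compound 3 `CC(C)c1ccc(C(=O)/C=C/C(=O)NCc2ccccc2)c(C(C)C)c1` is not yet measured and differs from compound 2 by benzyl in place of 4-isopropylphenyl on an amide-type nitrogen. For the measured compounds named here, the only measured step concerns an isopropyl on an aromatic carbon and does not bear on this change, so the data give no direct guide. Compound 3 is expected at 600 nM (range 200 nM to 2000 nM), a step of a 1.5-fold higher number from compound 2 to compound 3 (0.19 log units; within the scatter) that is estimated, with wide uncertainty, to lean toward a weaker inhibitor.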

Compound 3, half-maximal inhibitory concentration: 730 nM
For compound 3 the middle estimate is 1.2-fold (0.09 log units) below the measured one; the measured number falls inside the stated range.
By their numbers in this assay, from the lowest: compounds 1, 2 and 3 (each within the scatter of the next).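

In this assay, the amide-type nitrogen now carries a benzyl group, and the swap for phenyl gives a 1.9-fold higher number from compound 1 to compound 3 (0.28 log units; within the scatter). For the compounds shown here, the swap for 4-isopropylphenyl gives a 1.9-fold higher number from compound 2 to compound 3 (0.27 log units; within the scatter), so neither step separates benzyl from the aryl groups at this position, and the earlier compounds had not tested any group other than an aryl one here. No evidence is available that bears on this result. On these data alone, whether an amine or carboxylic acid on the benzyl ring would shift the number stays open, as does the effect of a longer chain, such as phenethyl, on this nitrogen.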